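The source may report more compounds than this note shows. Statements on the series, on what has been measured and on what is new or still open speak of the compounds shown alone.

Measured so far:
- compound 1, `CCCCc1cnc(C(Cc2ccc(-c3ccccc3C(=O)O)cc2)C(C)C)[nH]1`: 4620 nM
- compound 2, `N#Cc1ccc(Cc2cnc(CCc3ccc(-c4ccccc4C(=O)O)cc3)[nH]2)cc1`: 5890 nM

Both compounds were tested in an in vitro functional assay on cells for agonist activity at Bombesin receptor subtype-3 (Homo sapiens), read by luminescence and calcium flux; a lower number here means that less compound is needed, a higher number that more compound is needed for the effect. Compound 1 has the structure `CCCCc1cnc(C(Cc2ccc(-c3ccccc3C(=O)O)cc2)C(C)C)[nH]1` and in this assay compound 1 gives 4620 nM. Compound 2 has the structure `N#Cc1ccc(Cc2cnc(CCc3ccc(-c4ccccc4C(=O)O)cc3)[nH]2)cc1` and in this assay compound 2 gives 5890 nM. These two numbers lie within the usual scatter of each other, so neither compound can be called stronger or weaker than the other on the evidence at hand.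

The step of interest leads from compound 2 to compound 3, whose structure is `COc1ccccc1Cc1cnc(CCc2ccc(-c3ccccc3C(=O)O)cc2)[nH]1`. The change is 2-methoxyphenyl in place of 4-cyanophenyl on a saturated chain carbon bound to an aromatic carbon. Both the group that leaves and the group that enters carry a single hydrogen-bond acceptor and the same count of heavy atoms, and both are a six-membered aromatic ring of carbon only. For the measured compounds named here, no measured pair shows what such a swap does here, so there is nothing to lean on beyond the two numbers above. The expectation is a step from compound 2 to compound 3 of a 1.1-fold higher number from compound 2 to compound 3 (0.04 log units; within the scatter), that is, no change beyond the scatter. Compound 3 is therefore estimated at 6500 nM, with a range from 2500 nM to 17000 nM.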

Compound 3, half-maximal effective concentration: 1720 nM
The estimate for compound 3 lay 3.8-fold (0.58 log units) above the measured number; the whole stated range lies above it.
By their numbers in this assay, from the lowest: compound 3; then compounds 1 and 2 (each within the scatter of the next).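

For the compounds shown here, measured in this assay the change to 2-methoxyphenyl in place of 4-cyanophenyl on a saturated chain carbon bound to an aromatic carbon gives a 3.4-fold lower number from compound 2 to compound 3 (0.53 log units; beyond the scatter) and is the first comparison here in which the compounds differ in only one place. It shows that this position matters: the identity of the benzyl group changes how much compound is needed, and the step lies beyond the usual scatter. The change also keeps the counts of heavy atoms and hydrogen-bond acceptors and the six-membered aromatic ring the same, so those counts alone do not account for the difference, and nothing measured here gives a reason for it.

The two groups differ both in their substituent, nitrile or methoxy, and in the ring position given by their names, so this one step cannot show which of these differences matters. The compounds shown also leave open how this position would respond to an unsubstituted benzyl group, to a benzyl group carrying an amine or a chlorine atom, or to a simple alkyl chain such as butyl.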